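A few compounds are considered here, and "the series" means these few. Any claim that something is new, unique, unknown or untested is made for them only; others in the source may bear on it.

Working notes on the series. Three compounds carrying the same core with an aryl group on the sulfonyl sulfur have been measured in a functional assay on Umbilical vein for antagonist activity at B1 bradykinin receptor (Homo sapiens), using Schild analysis, with a stated time of 30 min; a lower number here means a less potent compound, a higher number a more potent compound, by a factor of ten per unit of this negative logarithm. Compound 3 `Cc1c(Cl)ccc(S(=O)(=O)N(C)CCOCC(=O)N(C)Cc2ccc(C3=NCCN3)cc2)c1Cl` gives 9.1. Compound 1 `CN(Cc1ccc(C2=NCCN2)cc1)C(=O)COCCN(C)S(=O)(=O)c1c(F)cccc1F` gives 7.6, and compound 2 `CN(Cc1ccc(C2=NCCN2)cc1)C(=O)COCCN(C)S(=O)(=O)c1ccc(OC(F)(F)F)cc1` gives 7.5. Compound 3 stands highest of the three: a number 1.50 log units higher from compound 1 to compound 3 (beyond the scatter) and a number 1.60 log units higher from compound 2 to compound 3 (beyond the scatter), so on these numbers compound 3 is the most potent. Between the other two, a number 0.10 log units lower from compound 1 to compound 2 (within the scatter).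

Compound 4 `Cc1c(Cl)cccc1S(=O)(=O)N(C)CCOCC(=O)N(C)Cc1ccc(C2=NCCN2)cc1` is not yet measured. The change from compound 3 is 3-chloro-2-methylphenyl in place of 2,4-dichloro-3-methylphenyl on a sulfonyl sulfur. Every measured step alters the aryl group at this same place, so all three bear on this step; none, however, tests 3-chloro-2-methylphenyl itself. For the measured compounds named here, the two large steps show that the aryl group on the sulfonyl sulfur can move this assay by a great deal, while the one aryl group found so far to give a high number is the 2,4-dichloro-3-methylphenyl of compound 3, which compound 4 gives up. A downward step is therefore expected, smaller than the full distance back to compound 1, because compound 3 with 9.1 and compound 4 share a chlorine and a methyl on that ring. For compound 4 the expected value is 8.1, with a range of 7.3 to 8.9. The expected step is a number 1.00 log units lower from compound 3 to compound 4 (beyond the scatter).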

Compound 4, negative logarithm of the antagonist equilibrium constant: 8
For compound 4 the middle estimate is 0.10 log units above the measured one, within the range that was stated.
By their numbers in this assay, from the lowest: compounds 2 and 1 (each within the scatter of the next); then compound 4; then compound 3.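

Going from 2,4-dichloro-3-methylphenyl to 3-chloro-2-methylphenyl on a sulfonyl sulfur gives a number 1.10 log units lower from compound 3 to compound 4 (beyond the scatter) in this assay, so keeping a chlorine and a methyl on the ring does not keep the high number of compound 3. The 3-chloro-2-methylphenyl group still gives a number 0.50 log units higher from compound 2 to compound 4 (beyond the scatter) and a number 0.40 log units higher from compound 1 to compound 4 (beyond the scatter), so this position now shows an intermediate level as well as the high and low levels seen earlier. No measurement at hand accounts for these differences.

Which part of the 2,4-dichloro-3-methylphenyl group carries the high number of compound 3 remains open, since compound 3 and compound 4 differ in both the chlorine count and the placing of the groups. As far as these compounds go, how a methoxy group or an amine on this ring would compare also remains open.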